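The source may hold more compounds than are shown below. What is called first, only, known or untested is meant among the compounds shown, and "the series" means these compounds.

Measured so far:
- Compound 1 `C#CCn1nnc2c(C(N)=O)ncn2c1=O`: 35600 nM
- Compound 2 `COc1cc(Cn2nnc3c(C(N)=O)ncn3c2=O)cc(OC)c1OC`: > 50000 nM, a limit of the assay and not a number

Both compounds were tested in a functional assay on SNB-19 cells (Homo sapiens) for inhibition, read by MTT assay, with a stated time of 7 days; on this read-out lower numbers stand for stronger inhibition of growth and higher numbers for weaker inhibition of growth. Among the measured compounds shown here, compound 1, at 35600 nM, holds the only actual number. The result for compound 2 is a limit.

Compound 3 `NC(=O)c1ncn2c(=O)n(Cc3ccsc3)nnc12` has not been measured yet. Its difference from compound 1 is thiophen-3-yl in place of ethynyl on a saturated chain carbon bound to an aromatic nitrogen. In short, this is propargyl to (thiophen-3-yl)methyl.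

For the measured compounds named here, no step between two measured compounds is available as a guide. Going by the values given here, the only anchor is compound 1 at 35600 nM. In this assay, the expected step of a 1.1-fold higher number from compound 1 to compound 3 (0.05 log units; within the scatter) stays within the usual scatter, so no clear change in either direction is expected.

For compound 3 the estimate is 40000 nM, with an expected range of 20000 nM to 80000 nM.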

Compound 3, concentration for 50% growth inhibition: > 50000 nM
Compound 3 gave a limit, no number; the forecaster's own chance of this, stated with the estimate: 45%; middle value at least 1.2-fold (0.09 log units) from the limit.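

Among the compounds shown here, the swap of propargyl for (thiophen-3-yl)methyl gives the first step that can be read at this position in this assay, and it is an at least 1.4-fold higher number from compound 1 to compound 3 (0.14 log units; that floor lies within the scatter). As far as these compounds go, compound 3 gives > 50000 nM, which is a limit of the assay and not a number, so the step is only a floor and the real size of the change remains unknown. Compound 1 therefore remains the only compound with an actual number, and the data can go no further in ranking the groups at this position: the limit of > 50000 nM in this assay, at which 2 of the 3 values shown sit.

The compounds shown leave open whether any group at this place can bring the number clearly lower than in compound 1. A plain butyl chain, or a chain ending in an amine or a carboxylic acid, would test this.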